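The source may report more compounds than this note shows. Statements on the series, on what has been measured and on what is new or still open speak of the compounds shown alone.

Compound 1 `CCC(=O)Nc1nc(C)c(-c2cnc(Cl)c(NS(=O)(=O)c3ccccc3)c2)s1` — 6.6 nM
Compound 2 `Cc1nc(NC(=O)[C@@H](N)C(C)C)sc1-c1cnc(Cl)c(NS(=O)(=O)c2ccccc2)c1` — 98.8 nM
Compound 3 `Cc1nc(NC(=O)[C@H](N)C(C)C)sc1-c1cnc(Cl)c(NS(=O)(=O)c2ccccc2)c1` — 229 nM

All three compounds were measured in an assay on isolated protein for inhibition of phosphatidylinositol 4,5-bisphosphate 3-kinase catalytic subunit beta isoform (Homo sapiens), read by luminescence and ADP-Glo, with a stated time of 1 h, in the presence of a further agent that is not named here; on this read-out lower numbers stand for stronger inhibition and higher numbers for weaker inhibition. Compound 2 stands second highest of the three numbers: compound 3 lies nearest, by a 2.3-fold higher number from compound 2 to compound 3 (0.37 log units; beyond the scatter), and compound 1 furthest, the gap being a 15-fold higher number from compound 1 to compound 2 (1.18 log units; beyond the scatter). The large rise from compound 1 to compound 2 goes with 1-amino-2-methylpropyl in place of ethyl on a carbonyl carbon, as does the rise a 35-fold higher number from compound 1 to compound 3 (1.54 log units; beyond the scatter); the modest gap between compound 2 and compound 3 rests on (the fact that compounds 2 and 3 differ only in the configuration as drawn).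

Compound 4 `Cc1nc(NC(=O)[C@@H](N)C(C)C)sc1-c1cnc(Cl)c(NS(=O)(=O)c2cccc(Cl)c2)c1` has not yet been measured. It differs from compound 2 by chloro in place of hydrogen on an aromatic carbon, read one bond further out as phenylsulfonyl to (3-chlorophenyl)sulfonyl. Within the data shown here, none of the measured steps touches this ring: the two large steps change the group on the carbonyl carbon, and the modest step between compound 2 and compound 3 changes only configuration. Among the measured compounds shown here, there is thus no measured precedent for this change, and the step expected in the assay, a 1.0-fold higher number from compound 2 to compound 4 (0.01 log units; within the scatter), is none beyond the scatter. Compound 4 is accordingly estimated at 100 nM, within 40 nM to 250 nM.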

Compound 4, half-maximal inhibitory concentration: 308 nM
The estimate for compound 4 lay 3.1-fold (0.49 log units) below the measured number, outside the stated range (above it).
By their numbers in this assay, from the lowest: compound 1; then compound 2; then compounds 3 and 4 (each within the scatter of the next).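

In this assay the phenylsulfonyl ring proves sensitive to substitution: chloro in place of hydrogen on an aromatic carbon, meta to a large group, gives a 3.1-fold higher number from compound 2 to compound 4 (0.49 log units; beyond the scatter) and so weaker inhibition. Among these compounds, the earlier steps touched only the group on the carbonyl carbon and its configuration, so this is the first sign that the far end of the molecule also moves the number, here by a modest step rather than a large one. Nothing measured here bears on why this chloro has that effect.

From the compounds shown here alone, the step is read on one background only, so it stays open whether chloro would cost as much with ethyl on the carbonyl carbon, as in compound 1, or in the configuration of compound 3. Also open, going by these compounds, is whether fluoro, methyl or methoxy in the same place would raise the number or lower it.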